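The source may hold more compounds than are shown below. What is called first, only, known or untested is meant among the compounds shown, and "the series" means these compounds.

Among the compounds with values here, in an ADME assay on MRC5 cells (Homo sapiens) for cytotoxicity, read by MTT assay, with a stated time of 72 h (on this read-out higher numbers stand for lower toxicity in this test and lower numbers for higher toxicity in this test), compound 1 `OC[C@H]1O[C@@H](n2cc(F)c3c(-c4cccs4)ncnc32)[C@H](O)[C@@H]1O` gives 47200 nM and compound 2 `OC[C@H]1O[C@@H](n2cc(F)c3c(-c4ccc[nH]4)ncnc32)[C@H](O)[C@@H]1O` gives 44500 nM, so compound 2 stands level with its only neighbour, within the scatter. Compound 3 `OC[C@H]1O[C@@H](n2cc(F)c3c(-c4cc[nH]c4)ncnc32)[C@H](O)[C@@H]1O` has the same atoms, joined differently: 1H-pyrrol-3-yl in place of 1H-pyrrol-2-yl on an aromatic carbon, with 1H-pyrrol-3-yl in place of 1H-pyrrol-2-yl on an aromatic carbon. Within the data shown here, the one measured step that bears on this swapped a different ring, a 1.1-fold lower number from compound 1 to compound 2 (0.03 log units; within the scatter), and it stayed within the scatter. It is only indirect evidence, but no change beyond the scatter is expected in this assay. The expected size is a 1.1-fold lower number from compound 2 to compound 3 (0.03 log units; within the scatter). The estimate for compound 3 is 42000 nM, with an expected range of 14000 nM to 64000 nM.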

Compound 3, half-maximal cytotoxic concentration: 48900 nM
Compound 3: the middle estimate sits 1.2-fold (0.07 log units) below what was measured; the measured number falls inside the stated range.
By their numbers in this assay, from the lowest: compounds 2, 1 and 3 (each within the scatter of the next).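

In this assay, moving the attachment from 1H-pyrrol-2-yl to 1H-pyrrol-3-yl on this aromatic carbon gives a 1.1-fold higher number from compound 2 to compound 3 (0.04 log units; within the scatter) and so leaves the number level, which shows that the point of attachment of the pyrrole does not register in this test. Replacing thiophen-2-yl with 1H-pyrrol-3-yl gives a 1.0-fold higher number from compound 1 to compound 3 (0.02 log units; within the scatter) and likewise leaves all three rings level at this position. No measurement is available that would explain this result. The compounds shown leave open whether a non-ring group at this carbon, such as an amine or a carboxylic acid, would shift the number.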